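Dropping the methoxy group from a quinoline carboxamide

The compounds below may be only part of what the source reports. "The series", "measured", "known", "first", "only" and "open" are said of these compounds alone.

Measured compounds:
compound 1, `Cc1c(C(=O)Nc2ccc(-c3ccccc3)cc2)nc2ccccc2c1O`, 21.5%
compound 2, `COc1ccc2nc(C(=O)Nc3ccc(-c4ccccc4)cc3)c(C)c(C(=O)O)c2c1`, 19.4%

Of the compounds shown here, two have been tested in a functional assay on Hep 3B2 cells (Homo sapiens) for antiproliferative activity, read by MTT assay, with a stated time of 24 h, tested at 3.7 ug/mL; a lower number here means a weaker effect, a higher number a stronger effect of the compound at the concentration tested. Compound 1 gives 21.5%, and compound 2 gives 19.4%. Compound 2 stands lowest of the two numbers, but its nearest neighbour is compound 1, whose value lies only a little higher, a gap within the scatter, so no order between the two can be read from the data.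

The next compound, compound 3, `Cc1c(C(=O)Nc2ccc(-c3ccccc3)cc2)nc2ccccc2c1C(=O)O`, is not yet measured. It differs from compound 2 in one place: hydrogen in place of methoxy on an aromatic carbon. Among the compounds with values here, no pair of measured compounds differing in a single place is available, so the size of such a step in this assay has no precedent here. Given that the two measured compounds, despite their different substitution, sit within the scatter of each other, the step from compound 2 to compound 3 is expected to be small, with no direction beyond the scatter, as a number 1.6 percentage points higher from compound 2 to compound 3 (within the scatter). Compound 3 is therefore expected to give about 21%, within a range from 8% to 36%.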

Compound 3, a percentage reported as inhibition, at one concentration (the size of the read-out at that concentration, not a potency): 2.31%
Beside the measured number, compound 3's estimate is 18.7 percentage points above it; the whole stated range lies above it.
By their numbers in this assay, from the lowest: compound 3; then compounds 2 and 1 (each within the scatter of the next).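

Within the data shown here, the methoxy group on this aromatic carbon is not a silent substituent in this assay: replacing it with hydrogen gives a number 17.1 percentage points lower from compound 2 to compound 3 (beyond the scatter), the first step that can be read beyond the scatter. The same end point is reached by a second single change, carboxy in place of hydroxy on an aromatic carbon, which gives a number 19.2 percentage points lower from compound 1 to compound 3 (beyond the scatter), so compound 3, the only one of the three that pairs the carboxy group with no methoxy, falls away from both neighbours, while the effect of each change is known only in this one setting. Nothing available explains why either step lowers the number.

Going by these compounds, it remains open whether the drop depends on methoxy specifically or whether another group on the same carbon, such as ethoxy, a chlorine atom or an amine, would keep the number near that of compound 2, and whether a methyl ester in place of the carboxy group would do the same for compound 3. Since these are readings at a single concentration, they tell only how strong the effect of each of the three compounds is at that concentration.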